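The compounds below may be only part of what the source reports. "The series", "measured", "known", "first", "only" and "open" are said of these compounds alone.

Working notes, series around the shared core of compound 1.

Three compounds have been run in a functional assay on NCI-H1975 cells (Homo sapiens) for cytotoxicity, read by MTT assay; on this read-out lower numbers stand for stronger inhibition and higher numbers for weaker inhibition. Compound 1 `C=CC(=O)Nc1cc(Nc2ncc(Cl)c(N3CCc4sccc4C3)n2)c(OC)cc1N1CCN(C)CC1` gives 197 nM. Compound 2 `C/C=C/C(=O)Nc1cc(Nc2ncc(Cl)c(N3CCc4sccc4C3)n2)c(OC)cc1N(C)CCN(C)C` gives 133 nM. Compound 3 `C=CC(=O)Nc1cc(Nc2ncc(Cl)c(N3CCc4sccc4C3)n2)c(OC)cc1N(C)CCN(C)C` gives 242 nM. The change from compound 1 to compound 3, (2-(dimethylamino)ethyl)(methyl)amino in place of 4-methylpiperazin-1-yl on an aromatic carbon, reads a 1.2-fold higher number from compound 1 to compound 3 (0.09 log units; within the scatter). The change from compound 2 to compound 3, vinyl in place of prop-1-en-1-yl on a carbonyl carbon, reads a 1.8-fold higher number from compound 2 to compound 3 (0.26 log units; within the scatter). Compound 3 is thus nearest to compound 1 and furthest from compound 2, and neither gap is beyond the scatter.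

Compound 4 `C=C(Cl)C(=O)Nc1cc(Nc2ncc(Cl)c(N3CCc4sccc4C3)n2)c(OC)cc1N(C)CCN(C)C` is not yet measured. It differs from compound 3 by chloro in place of hydrogen on a double-bonded chain carbon bound to a carbonyl carbon. For the measured compounds named here, of the measured steps, only the one from compound 2 to compound 3 touches the same double-bonded chain carbon, and that step stayed within the scatter; the step from compound 1 to compound 3 lies elsewhere and also stayed within the scatter. Going by the values given here, no measured pair shows chloro against hydrogen at this place. The expectation is therefore no step beyond the scatter in this assay, with compound 4 estimated at 240 nM, range 100 nM to 600 nM. The expected step is a 1.0-fold lower number from compound 3 to compound 4 (0.00 log units; within the scatter).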

Compound 4, half-maximal inhibitory concentration: 92 nM
Compound 4: middle estimate off by 2.6-fold (0.42 log units), on the high side, outside the stated range (below it).
By their numbers in this assay, from the lowest: compounds 4, 2, 1 and 3 (each within the scatter of the next, the first and the last beyond it).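

In this assay, for the compounds shown here, chloro in place of hydrogen on a double-bonded chain carbon bound to a carbonyl carbon gives a 2.6-fold lower number from compound 3 to compound 4 (0.42 log units; beyond the scatter), the only step so far that lies beyond the scatter, so this position does register a single-atom change on this read-out. Set against prop-1-en-1-yl, 1-chloroethenyl gives a 1.4-fold lower number from compound 2 to compound 4 (0.16 log units; within the scatter), which stays within the scatter, so these two groups cannot be told apart here, and only vinyl against 1-chloroethenyl separates. Nothing at hand accounts for the step from vinyl to 1-chloroethenyl.

On these data alone, it remains open whether the step is particular to chloro or would also appear with fluoro, bromo or a nitrile on the same double-bonded chain carbon. It is equally open whether 1-chloroethenyl gives a step of similar size with 4-methylpiperazin-1-yl in place of (2-(dimethylamino)ethyl)(methyl)amino on the aromatic carbon, as that pairing is absent from the compounds shown.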